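Anomeric stereocentre inverted in glucopyranosyl carboxanilide

The source may report more compounds than this note shows. Statements on the series, on what has been measured and on what is new or still open speak of the compounds shown alone.

Three compounds of the shared glucopyranosyl core have numbers in an assay on isolated protein (Oryctolagus cuniculus) for binding affinity to glycogen phosphorylase, brain form (Homo sapiens); on this read-out higher numbers stand for weaker inhibition and lower numbers for stronger inhibition. Compound 1 `O=C(Nc1ccccc1)[C@@H]1OC(CO)C(O)C(O)C1O` gives 5400000 nM and stands second highest of the three. Compound 3 `NCC[C@@H]1OC(CO)C(O)C(O)C1O` gives 4500000 nM, a gap to compound 1 that lies within the scatter, so no order between these two is claimed. Within the data shown here, compound 2 `C[C@H]1OC(CO)C(O)C(O)C1O` gives 53100000 nM, which is the only value beyond the scatter from compound 1 and is the higher one. Among the measured compounds shown here, no pair among the measured compounds differs in one place only, so no single step is available for calibration.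

Compound 4 `O=C(Nc1ccccc1)[C@H]1OC(CO)C(O)C(O)C1O` is to be measured in this assay. It differs from compound 1 as follows: the two compounds have the same atoms and bonds; at least one stereo element is drawn with a configuration in one of them and without one in the other: 1 of 5 stereo elements differ; a stereocentre at a saturated ring carbon is drawn R in compound 1 and S in compound 4. The change keeps every atom and bond and alters only the drawn configuration at one ring carbon. For the measured compounds named here, nothing among the measured compounds tests a change of this kind, so the size of the step is unknown from the data and the expectation is correspondingly wide. An increase in the number, that is weaker inhibition, is expected as the more likely direction, with a step from compound 1 to compound 4 of a 3.7-fold higher number from compound 1 to compound 4 (0.57 log units; beyond the scatter), but a step within the scatter cannot be excluded. Compound 4 is estimated at 20000000 nM, with a range from 4000000 nM to 100000000 nM.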

Compound 4, inhibition constant: 12600000 nM
For compound 4 the middle estimate is 1.6-fold (0.20 log units) above the measured one; the measured number falls inside the stated range.
By their numbers in this assay, from the lowest: compounds 3 and 1 (each within the scatter of the next); then compound 4; then compound 2.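

Among these compounds, changing only the drawn configuration at this saturated ring carbon, with every atom and bond kept, gives a 2.3-fold higher number from compound 1 to compound 4 (0.37 log units; beyond the scatter) in this assay, the first step that can be read at a single place. Configuration alone therefore moves the number beyond the scatter at this position, towards weaker inhibition with the S drawing, although the step is modest and the carboxanilide group stays in place on both sides. The step needs one caution when read as a clean exchange of one configuration for the other, since the two drawings may not be equally defined: the fact that one of compounds 1 and 4 is drawn with a defined configuration and the other without, at the place where they differ

As far as these compounds go, whether this configuration has a step of similar size and the same direction with a carboxylic acid or a primary carboxamide in place of the carboxanilide remains open. Also open, from the compounds shown here alone, is whether a methoxy group on the phenyl ring, or a longer chain between the carbonyl and the phenyl ring, would widen or narrow the gap between the two configurations.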